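Nitro substitution on the fused ring of compound 1

The source may report more compounds than this note shows. Statements on the series, on what has been measured and on what is new or still open speak of the compounds shown alone.

Measured compounds:
compound 1 `O=c1cc(-c2ccccc2)oc2cc(N3COc4ccccc4C3)ccc12`: 2.65%
compound 2 `O=c1cc(-c2ccccc2)oc2ccc(N3COc4c(Cl)cc(Cl)cc4C3)cc12`: 32.8%
compound 3 `O=c1cc(-c2ccccc2)oc2ccc(N3COc4ccccc4C3)cc12`: 8.7%

In a functional assay on MCF7 cells (Homo sapiens) for inhibition, read by MTT assay, with a stated time of 48 h, tested at 7.5 ug/mL (on this read-out higher numbers stand for more inhibition of growth at the one concentration tested and lower numbers for less inhibition of growth), compound 1 gives 2.65%, the lowest of the three numbers. Compound 3 sits nearest to it, and the two values lie within the usual scatter of this assay, so no order between compound 1 and compound 3 can be read. Compound 2 lies furthest from compound 1, and that gap is beyond the scatter; compound 2 carries two chlorine atoms on its fused ring, and its value is the only one of the three that stands clearly apart.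

Compound 4 `O=c1cc(-c2ccccc2)oc2cc(N3COc4c(cccc4[N+](=O)[O-])C3)ccc12` is not yet measured. It differs from compound 1 in one place: nitro in place of hydrogen on an aromatic carbon. For the measured compounds named here, no pair of measured compounds shows this change, so the size of the step rests on the spread of the measured values alone. A moderate rise is expected, as substitution on the fused ring in compound 2 goes with the higher number, though that comparison is not a clean one. The step from compound 1 to compound 4 is estimated at a number 12.4 percentage points higher from compound 1 to compound 4 (beyond the scatter). Compound 4 is expected to give about 15%, with a range from 0% to 35%.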

Compound 4, percent growth inhibition at one concentration: "not active" (no number reported)
Nothing numeric was reported for compound 4; the estimate stays without a comparison.
By their numbers in this assay, from the lowest: compounds 1 and 3 (each within the scatter of the next); then compound 2.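

For the compounds shown here, compound 4 is reported as not active, with no number, so no step from compound 1 to compound 4 can be read. No measurement at hand explains this result. The compounds shown leave open how far nitro in place of hydrogen shifts growth inhibition.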